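Swapping the aryl amide of a kinase inhibitor for an isoxazole

The compounds below may be only part of what the source reports. "The series", "measured", "known", "first", "only" and "open" are said of these compounds alone.

Of the compounds shown here, three built on a shared bis-amide core have been measured in an assay on isolated protein for inhibition of Rho-associated protein kinase 2 (Homo sapiens), read by scintillation counting, radiometric assay and 33P incorporation, with a stated time of 40 min, in the presence of a further agent that is not named here; on this read-out higher numbers stand for weaker inhibition and lower numbers for stronger inhibition. Compound 1 `CN(C)c1ccc(C(=O)Nc2cccc(NC(=O)COc3ccc4c(c3)OCCC4=O)c2)cc1` gives 85 nM. Compound 2 `Cc1coc2cc(OCC(=O)Nc3cccc(NC(=O)c4ccc(N(C)C)cc4)c3)ccc2c1=O` gives 2150 nM. Compound 3 `CC(C)(C)c1ccc(C(=O)Nc2cccc(NC(=O)COc3ccc4c(=O)ccoc4c3)c2)cc1` gives 34 nM, the lowest number of the three: compound 1 stands at a higher number and compound 2 at a still higher number, both gaps lying beyond the usual scatter, so compound 3 is the strongest inhibitor among the measured set.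

Compound 4 `CC(C)(C)c1cc(C(=O)Nc2cccc(NC(=O)COc3ccc4c(=O)ccoc4c3)c2)no1` has not yet been measured. It differs from compound 3 in one place: 5-(tert-butyl)-1,2-oxazol-3-yl in place of 4-(tert-butyl)phenyl on a carbonyl carbon. Going by the values given here, no measured pair in this set shows what such a change does, so the expectation rests on compound 3 alone. He expects the step of a 1.9-fold higher number from compound 3 to compound 4 (0.28 log units; within the scatter) to be a small move toward weaker inhibition, likely within or just beyond the scatter. In this assay compound 4 is therefore estimated at 65 nM, with a range from 20 nM to 220 nM.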

Compound 4, half-maximal inhibitory concentration: 5 nM
Compound 4: middle estimate off by 13-fold (1.11 log units), on the high side; measured number outside the range, below it.
By their numbers in this assay, from the lowest: compound 4; then compound 3; then compound 1; then compound 2.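

In this assay, putting 5-(tert-butyl)-1,2-oxazol-3-yl in place of 4-(tert-butyl)phenyl on a carbonyl carbon gives a 6.8-fold lower number from compound 3 to compound 4 (0.83 log units; beyond the scatter). This shows that the ring at this position need not be a six-membered aromatic ring of carbon only: a five-membered aromatic ring with 2 hetero atoms is not merely accepted here but goes with stronger inhibition. Nothing available here explains why the number falls with this change.

The compounds shown leave open whether the gain depends on the tert-butyl group, and whether a cyclopropyl or a trifluoromethyl group on the same 1,2-oxazole would keep it. Also open, from the compounds shown here alone, is whether the same change would lower the number on the core of compound 1 as well.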